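Methoxy in Place of Bromo: What to Expect Next

The compounds below may be only part of what the source reports. "The series", "measured", "known", "first", "only" and "open" are said of these compounds alone.

Compound 3 `Nc1scc(-c2cccc(Br)c2)c1C(=O)c1ccccc1` stands second highest of the three numbers in a functional assay on CHO cells for agonist activity at adenosine receptor A1 (Homo sapiens), read by fluorescence and ERK phosphorylation, with stated times of 30 min and 1.5 h, tested at 3 uM (a higher number here means a stronger effect of the compound at the concentration tested, a lower number a weaker effect), where compound 3 gives 67%. Its nearest neighbour is compound 1 `Nc1scc(-c2cccc(C(F)(F)F)c2)c1C(=O)c1ccccc1`, which gives 83%; the furthest is compound 2 `Nc1scc(-c2cccc(Cl)c2)c1C(=O)c1ccccc1`, which gives 45%. Compound 4 `COc1cccc(-c2csc(N)c2C(=O)c2ccccc2)c1` differs from compound 3 in one place: methoxy in place of bromo on an aromatic carbon. For the measured compounds named here, no measured step involves a methoxy group, so only the swaps among halogens and trifluoromethyl at the same place bear on it: a number 16 percentage points lower from compound 1 to compound 3 (beyond the scatter), a number 22 percentage points higher from compound 2 to compound 3 (beyond the scatter) and a number 38 percentage points lower from compound 1 to compound 2 (beyond the scatter). Small changes there shifted the read-out by modest to large amounts in both directions. A downward step of a number 17 percentage points lower from compound 3 to compound 4 (beyond the scatter) is therefore expected, with wide uncertainty. Compound 4 is estimated at 50%, ranging from 25% to 78%.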

Compound 4, a percentage reported as activity, at one concentration (the size of the read-out at that concentration, not a potency): 41%
The estimate for compound 4 lay 9 percentage points above the measured number; measured number inside the range.
By their numbers in this assay, from the lowest: compounds 4 and 2 (each within the scatter of the next); then compound 3; then compound 1.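

Methoxy, with its oxygen, lands low at this place on the ring: replacing bromo gives a number 26 percentage points lower from compound 3 to compound 4 (beyond the scatter) in this assay and replacing trifluoromethyl gives a number 42 percentage points lower from compound 1 to compound 4 (beyond the scatter) on the same read-out. Replacing chloro gives a number 4 percentage points lower from compound 2 to compound 4 (within the scatter) and so leaves those two compounds level. The order at this place therefore now spans a group containing oxygen as well as the halogens and trifluoromethyl.

On these data alone, whether an amine or a hydroxyl group here would read closer to compound 1 or to compound 4 remains open. Nothing available gives a reason for these steps.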